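The source may report more compounds than this note shows. Statements on the series, on what has been measured and on what is new or still open speak of the compounds shown alone.

Of the compounds shown here, three built on one shared core have so far been tested in a functional assay on A549 cells (Homo sapiens) for cytotoxicity, read by MTT assay, with a stated time of 72 h; a higher number here means a weaker inhibitor, a lower number a stronger inhibitor. Compound 1 `O=C1c2c[n+]([O-])c3ccccc3c2C(=O)c2c1c1ccccc1n2Cc1cn([C@@H]2C[C@H](O)[C@@H](CO)O2)nn1` gives 120 nM. Among the measured compounds shown here, compound 3 `CC1(C)OC[C@@H](Cn2cc(Cn3c4c(c5ccccc53)C(=O)c3c[n+]([O-])c5ccccc5c3C4=O)nn2)O1` gives 4700 nM, and the single change between these two, a 39-fold higher number from compound 1 to compound 3 (1.59 log units; beyond the scatter), shows that the group carried on the aromatic nitrogen can move the result a long way. Compound 2 `CCCCN1CCN(CCCCn2c3c(c4ccccc42)C(=O)c2c[n+]([O-])c4ccccc4c2C3=O)CC1` gives 550 nM. Among the three numbers compound 2 stands second highest: compound 1 is its nearer neighbour and compound 3 the further one, and both gaps lie beyond the scatter.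

Compound 4 `O=C1c2c[n+]([O-])c3ccccc3c2C(=O)c2c1c1ccccc1n2CCCN1CCC(O)CC1` is the next compound and has not yet been measured. It differs from compound 2 in one place: 4-hydroxypiperidin-1-yl in place of (4-butylpiperazin-1-yl)methyl on a saturated chain carbon, three bonds along the chain from an aromatic nitrogen. For the measured compounds named here, none of the measured steps changes this part of the molecule. The step from compound 1 to compound 3 is the only one available, and it alters the group sitting directly on the aromatic nitrogen rather than a group three bonds along the chain, so it shows only that this region of the structure matters. Without a closer comparison, a modest weakening rather than a large one is expected, and the step is estimated as a 1.5-fold higher number from compound 2 to compound 4 (0.16 log units; within the scatter). The value expected for compound 4 is 800 nM, with a range from 250 nM to 2500 nM.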

Compound 4, half-maximal inhibitory concentration: 350 nM
Compound 4: middle estimate off by 2.3-fold (0.36 log units), on the high side; low and high end bracket the measured number.
By their numbers in this assay, from the lowest: compound 1; then compounds 4 and 2 (each within the scatter of the next); then compound 3.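

Replacing (4-butylpiperazin-1-yl)methyl with 4-hydroxypiperidin-1-yl on a saturated chain carbon, three bonds along the chain from an aromatic nitrogen, gives a 1.6-fold lower number from compound 2 to compound 4 (0.20 log units; within the scatter) in this assay and so leaves the two compounds indistinguishable in this assay. Among the compounds shown here, this is the first look at this position, and it shows that a group of 7 heavy atoms with one hydrogen-bond donor reads the same as one of 11 heavy atoms with no donor, even though the butyl group and the second ring nitrogen are gone. Nothing shown here accounts for this similarity.

Several features change together in this one step, so the compounds shown cannot separate the contribution of the hydroxyl group from that of the butyl group, the ring nitrogen or the chain holding the ring. On these data alone, it remains open whether a plain piperidine, a morpholine, a simple dimethylamine or a longer chain at the same place would also stay within the scatter of these two compounds.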